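The compounds below may be only part of what the source reports. "The series", "measured", "known", "first", "only" and "open" are said of these compounds alone.

Compound 3 `Cc1cccc(-c2nnc(-c3nn(C)c4ccccc34)o2)c1` is reported only as a limit of the assay: in an ADME assay on L02 cells (Homo sapiens) for cytotoxicity, read by MTT assay, with a stated time of 72 h (a lower number here means a stronger inhibitor, a higher number a weaker inhibitor), compound 3 gives > 100000 nM. Compound 2 `Cn1nc(-c2nnc(-c3ccccc3Cl)o2)c2ccccc21` likewise gives a limit, > 100000 nM in this assay. Compound 1 `Cn1nc(-c2nnc(-c3ccccc3)o2)c2ccccc21` gives a number, 84600 nM in this assay. Both measured steps carry only a floor: an at least 1.1-fold higher number from compound 1 to compound 2 (0.07 log units; that floor lies within the scatter) and an at least 1.1-fold higher number from compound 1 to compound 3 (0.07 log units; that floor lies within the scatter), while a step that the two limits leave unreadable from compound 2 to compound 3. The change to compound 4 `Cn1nc(-c2nnc(-c3cccc(Br)c3)o2)c2ccccc21` is bromo in place of methyl on an aromatic carbon. Among the measured compounds shown here, no measured step covers this exchange; the nearest comparisons, chloro and methyl entering the phenyl ring, both end at the limit of > 100000 nM in this assay, at which 2 of the 3 values shown sit. A step beyond the scatter is therefore not expected, and a further limit is likely. Compound 4 is expected at 100000 nM (range 50000 nM to 200000 nM). The step of a number no higher from compound 3 to compound 4 (the limit leaves the size open) is expected to be flat.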

Compound 4, half-maximal inhibitory concentration: > 100000 nM
Compound 4 was reported as a limit (the forecaster's own chance of this, stated with the estimate: 65%); the middle value sits exactly at the limit.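

In this assay, among the compounds shown here, the change from methyl to bromo on the 3-substituted phenyl ring gives another limit rather than a number, so a halogen at this position joins the earlier limits: the limit of > 100000 nM in this assay, at which 3 of the 4 values shown sit. The one readable step is an at least 1.1-fold higher number from compound 1 to compound 4 (0.07 log units; that floor lies within the scatter). The steps among compound 2, compound 3 and compound 4 cannot be read.

On these data alone, how far these three compounds differ remains open, since their limits hide any true values. Also open, as far as these compounds go, is whether an amine or a carboxylic acid on the phenyl ring would give a measurable number in this assay.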